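The source may hold more compounds than are shown below. What is called first, only, known or untested is meant among the compounds shown, and "the series" means these compounds.

Compound 1 `COc1ccc(Nc2nc(-c3cccc(F)c3)nc3ccc(F)cc23)cc1` gives 38600 nM in a functional assay on HL-60 cells (Homo sapiens) for cytotoxicity, read by MTT assay, with a stated time of 48 h; on this read-out lower numbers stand for stronger inhibition and higher numbers for weaker inhibition. Compound 2 `Fc1cccc(-c2nc(Nc3cccc(Cl)c3)c3cc(F)ccc3n2)c1` reports no number in this assay but only its limit, > 50000 nM, which is where it sits (the limit of > 50000 nM in this assay, at which 1 of the 2 values shown sits). Among the measured compounds shown here, the one measured change, an at least 1.2-fold higher number from compound 1 to compound 2 (0.11 log units; that floor lies within the scatter), therefore shows only a floor and stays within the usual scatter.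

Compound 3 `Fc1cccc(-c2nc(Nc3ccccc3Br)c3cc(F)ccc3n2)c1` differs from compound 2 in a single place: 2-bromophenyl in place of 3-chlorophenyl on a nitrogen on an aromatic ring. For the measured compounds named here, no measured step covers this swap, so the expected step that the limit leaves unreadable from compound 2 to compound 3 is none beyond the scatter, in this assay. Compound 3 is accordingly estimated at 60000 nM, with a range from 25000 nM to 150000 nM.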

Compound 3, half-maximal inhibitory concentration: > 50000 nM
Compound 3: a limit, no number; the forecaster's own chance of this, stated with the estimate: 70%; the middle value is on the limit's open side.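

Compound 3 also gives only a limit in this assay, > 50000 nM, not a number. Among the compounds shown here, the swap from 3-chlorophenyl to 2-bromophenyl therefore cannot be sized, and the one readable step is an at least 1.2-fold higher number from compound 1 to compound 3 (0.11 log units; that floor lies within the scatter), which is only a floor. Compounds 2 and 3, with different halogen-carrying phenyl groups on this nitrogen, now share one limit: the limit of > 50000 nM in this assay, at which 2 of the 3 values shown sit.

As far as these compounds go, whether a 4-hydroxyphenyl or 4-aminophenyl group here would give a number under that limit stays open. So does the result of replacing the aromatic ring on this nitrogen with a plain butyl chain.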